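Swapping the Amine Chain for an Aminomethylphenyl Group

The source may report more compounds than this note shows. Statements on the series, on what has been measured and on what is new or still open speak of the compounds shown alone.

Compound 1 `c1cncc(CN(CCCCN(C[C@H]2Cc3ccccc3CN2)[C@H]2CCCc3cccnc32)Cc2cccnc2)c1` gives > 30000 nM in a functional assay on cells for agonist activity at C-X-C chemokine receptor type 4 (Homo sapiens), read by fluorescence and calcium flux, with a stated time of 90 s (on this read-out higher numbers stand for an effect only at larger amounts of compound and lower numbers for an effect already at smaller amounts), which is a limit of the assay and not a number.
Compound 2 `c1ccc2c(c1)CN[C@@H](CN(CCCCNCC1CCCCC1)[C@H]1CCCc3cccnc31)C2` gives > 30000 nM in this assay, again only a limit.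
Compound 3 `O=S1(=O)CCC(NCCCCN(C[C@H]2Cc3ccccc3CN2)[C@H]2CCCc3cccnc32)CC1` gives > 30000 nM in this assay, also a limit.

Compound 2 therefore stands nowhere on a numerical scale in this assay: it is known only by its limit, and the two other values shown are limits as well. Going by the values given here, the one measured step that changes a single place, a step that the two limits leave unreadable from compound 2 to compound 3, cannot be read in size or direction, because of the limit of > 30000 nM in this assay, at which 3 of the 3 values shown sit. Compound 4 `NCc1ccccc1CN(C[C@H]1Cc2ccccc2CN1)[C@H]1CCCc2cccnc21` differs from compound 2 by 2-(aminomethyl)phenyl in place of 3-((cyclohexylmethyl)amino)propyl on a saturated chain carbon bound to an amine nitrogen. Among the compounds with values here, no measured step bears on this particular change, since the only step between measured compounds leaves both ends at the same limit. With every value shown sitting at the limit, the expectation for compound 4 rests on that uniformity alone: the step from compound 2 to compound 4 is expected to be a number no higher from compound 2 to compound 4 (the limit leaves the size open), which is to say no change beyond the scatter is anticipated. Compound 4 is accordingly estimated at 30000 nM in this assay, within a range from 10000 nM to 100000 nM, and most likely reported again only as a limit.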

Compound 4, half-maximal effective concentration: > 30000 nM
Compound 4: a limit, no number (the forecaster's own chance of this, stated with the estimate: 85%); the middle value sits exactly at the limit.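

Compound 2 and compound 4 both sit at a limit rather than a number, so no new step can be read between them, in size or in direction: the limit of > 30000 nM in this assay, at which 4 of the 4 values shown sit.

The compounds shown leave open whether 2-(aminomethyl)phenyl and 3-((cyclohexylmethyl)amino)propyl differ at all in this assay, and which changes to the shared core would give a measurable number there.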